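The source may report more compounds than this note shows. Statements on the series, on what has been measured and on what is new or still open speak of the compounds shown alone.

Measured compounds:
Compound 1 `CN(C)C12CC(O)C(C(c3ccccc3)C1)C(c1ccccc1)C2` gives 133000 nM in an ADME assay on L6 cells (Rattus norvegicus) for cytotoxicity; on this read-out higher numbers stand for weaker inhibition and lower numbers for stronger inhibition.
Compound 2 `OC1CC2(N3CCCC3)CC(c3ccccc3)C1C(c1ccccc1)C2` gives 26800 nM in this assay.
Compound 3 `CN(C)C12CC(O)C(C(c3ccc(Cl)cc3)C1)C(c1ccc(Cl)cc1)C2` gives 8770 nM in this assay.

Of the compounds shown here, three built on bridged cores have been measured in this assay, and a fourth, compound 4 `OC1CC2(N3CCCC3)CC(c3ccc(Cl)cc3)C1C(c1ccc(Cl)cc1)C2`, awaits its reading. Compound 1 and compound 2 share a core and differ in one place: pyrrolidin-1-yl in place of dimethylamino on a saturated ring carbon. That change brought a 5.0-fold lower number from compound 1 to compound 2 (0.70 log units; beyond the scatter). Compound 3 carries the same dimethylamino group on a core bearing two 4-chlorophenyl groups; the difference between its core and the core of compound 1 is not broken down here, but in this assay compound 3 stands lowest of the three, with compound 2 nearest and compound 1 furthest from it.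

Compound 4 relates to compound 3 in the same kind of change: pyrrolidin-1-yl in place of dimethylamino on a saturated ring carbon. The surroundings of the place are not word for word the same, since in compound 3 one neighbouring ring atom bears a 4-chlorophenyl group where the corresponding atom in compound 1 bears a phenyl group. Because the change from compound 1 to compound 2 gave a 5.0-fold lower number from compound 1 to compound 2 (0.70 log units; beyond the scatter), a step of similar size is expected from compound 3 to compound 4, namely a 4.4-fold lower number from compound 3 to compound 4 (0.64 log units; beyond the scatter). On that basis compound 4 is estimated at 2000 nM in this assay. The range expected for compound 4 runs from 800 nM to 5000 nM.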

Compound 4, half-maximal inhibitory concentration: 3590 nM
Compound 4: the middle estimate sits 1.8-fold (0.25 log units) below what was measured; the measured number falls inside the stated range.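

In this assay, pyrrolidin-1-yl in place of dimethylamino on the core bearing two 4-chlorophenyl groups gave a 2.4-fold lower number from compound 3 to compound 4 (0.39 log units; beyond the scatter), the same direction as on the core of compound 1, and the two steps cannot be told apart in size: the same change on two cores in this assay, a 5.0-fold lower number (0.70 log units; beyond the scatter) from compound 1 to compound 2 and a 2.4-fold lower number (0.39 log units; beyond the scatter) from compound 3 to compound 4, 2.0-fold (0.31 log units) apart, within the scatter of two such steps. Within these four compounds, the change therefore carried over from one core to the other, with neither pair going against it. Within the data shown here, this rests on only two pairs in a single cell assay, so it gives no rule for other cores, and the gap between the steps is too small to show that the core alters the size of the change.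

It remains open whether the lower numbers go with pyrrolidin-1-yl in particular or would also appear with other amines, such as piperidin-1-yl, morpholin-4-yl or diethylamino, none of which stands among these compounds. Also open, from the compounds shown here alone, is how the same change would behave with other groups on the phenyl rings, such as fluoro or methoxy, or with a carbonyl in place of the hydroxy group.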